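A few compounds are considered here, and "the series" means these few. Any claim that something is new, unique, unknown or untested is made for them only; others in the source may bear on it.

Measured compounds:
compound 1 `O=C(Nc1[nH]nc(-c2ccccn2)c1C1CC1)c1c(Cl)cccc1Cl` — > 64000 nM
compound 2 `COc1ccc(C(=O)Nc2cc(-c3ccccn3)n[nH]2)cc1` — > 40300 nM
compound 3 `O=C(Nc1cc(-c2ccccn2)n[nH]1)N1CCC(c2cccc(Cl)c2)CC1` — > 22000 nM

The read-out is an ADME assay on cells (Peritoneal macrophage cell, Mus musculus) for cytotoxicity, read by fluorescence and resazurin assay, with a stated time of 3 days; a higher number here means that more compound is tolerated, a lower number that less compound is tolerated. For compound 1 the value is a limit of the assay and not a number: the limit of > 64000 nM in this assay, at which 1 of the 3 values shown sits. Compound 2 likewise sits at a limit of the assay, (the limit of > 40300 nM in this assay, at which 1 of the 3 values shown sits). Compound 3 also sits at a limit of the assay, (the limit of > 22000 nM in this assay, at which 1 of the 3 values shown sits). Every value shown is a limit. Among the measured compounds shown here, none of the three compounds can be placed above or below another, and no step between measured compounds can be worked out. Compound 1 therefore stands simply among the tolerated compounds, with no number of its own.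

Compound 4 `O=C(NCc1ccccc1)Nc1[nH]nc(-c2ccccn2)c1C1CC1` has not yet been run in this assay. It differs from compound 1 in one place: benzylamino in place of 2,6-dichlorophenyl on a carbonyl carbon.

Nothing in the measured set points to a change in tolerance in either direction, so the expected step from compound 1 to compound 4 is none beyond the scatter, which is what the estimated step of a number no higher from compound 1 to compound 4 (the limit leaves the size open) means. Compound 4 is expected to give about 64000 nM in this assay, within a range from 20000 nM to 200000 nM. This rests on compound 1 giving only > 64000 nM, so a further limit rather than a number is the likely outcome.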

Compound 4, half-maximal cytotoxic concentration: > 45000 nM
Compound 4: no number, only a limit (the forecaster's own chance of this, stated with the estimate: 75%); the middle value is on the limit's open side.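

In this assay compound 4 gives > 45000 nM, a limit of the assay and not a number. Among the compounds shown here, compound 1 gives > 64000 nM, also a limit, so no step from compound 1 to compound 4 can be read. The compounds shown leave open at what concentration any of them becomes cytotoxic, and whether benzylamino in place of 2,6-dichlorophenyl on a carbonyl carbon changes tolerance at all.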